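Adding a Second Chloro Group to the Shared Core

The source may report more compounds than this note shows. Statements on the series, on what has been measured and on what is new or still open speak of the compounds shown alone.

Compound 1 `ClCc1cccc(Cn2cnc3ncnc(Cl)c32)c1` and compound 2 `ClCc1ccccc1Cn1cnc2ncnc(Cl)c21` are built from the same atoms joined differently; the difference between the two cores is not broken down here. In a functional assay on NCI-H522 cells (Homo sapiens) for cytotoxicity, read by sulforhodamine B assay, with a stated time of 48 h (a higher number here means a weaker inhibitor of growth, a lower number a stronger inhibitor of growth), compound 1 gives 6160 nM and compound 2 gives 2810 nM. Compound 3 `ClCc1cccc(Cn2cnc3nc(Cl)nc(Cl)c32)c1` arises from compound 1 by chloro in place of hydrogen on an aromatic carbon, and in this assay compound 3 gives 1810 nM, a step of a 3.4-fold lower number from compound 1 to compound 3 (0.53 log units; beyond the scatter). Compound 4 `ClCc1ccccc1Cn1cnc2nc(Cl)nc(Cl)c21` is not yet measured; it arises from compound 2 by the same change, (chloro in place of hydrogen on an aromatic carbon), at a place described in exactly the same words. A step of similar size is expected from compound 2 to compound 4, though perhaps a little smaller, because the step of a 3.4-fold lower number from compound 1 to compound 3 (0.53 log units; beyond the scatter) rests on a single pair of compounds. Compound 4 is therefore expected to reach about 1000 nM in this assay, most likely between 400 nM and 2500 nM, an expected step of a 2.8-fold lower number from compound 2 to compound 4 (0.45 log units; beyond the scatter).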

Compound 4, concentration for 50% growth inhibition: 2950 nM
For compound 4 the middle estimate is 3.0-fold (0.47 log units) below the measured one, and the stated range ends below it.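

Putting chloro in place of hydrogen on the aromatic carbon between two ring nitrogen atoms gives a 1.0-fold higher number from compound 2 to compound 4 (0.02 log units; within the scatter) in this assay, so on this core the change shifts the number by no more than the usual scatter. The same change therefore does not carry over unchanged between these two cores: the same change on two cores in this assay, a 3.4-fold lower number (0.53 log units; beyond the scatter) from compound 1 to compound 3 and a 1.0-fold higher number (0.02 log units; within the scatter) from compound 2 to compound 4, 3.6-fold (0.55 log units) apart, beyond the scatter of two such steps. This shows that the size of the step can depend on the core, but two pairs of compounds cannot show what about the cores causes the difference, or what the step would be on any other core.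

The compounds shown carry only hydrogen or chloro at this place, so how an amine or a methoxy group there would compare remains open. Whether the two cores would also part ways in other cells is open as well.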